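Ester variation on the shared core: compound 2 to compound 3

The source may hold more compounds than are shown below. What is called first, only, known or untested is meant among the compounds shown, and "the series" means these compounds.

Two members of this series have been tested in a functional assay on MCF7 cells (Homo sapiens) for antiproliferative activity, read by MTT assay, with a stated time of 72 h; on this read-out higher numbers stand for weaker inhibition and lower numbers for stronger inhibition. Compound 1, `CC1=CCC2C(CC[C@@]2(C)O)C(C)(C)C1CC[C@@H]1[C@@]2(C)CCC(=O)C(C)(C)O[C@@H]2CC[C@]1(C)O`, returns no number but only the assay limit > 50000 nM. Compound 2, `CC1=CC[C@H]2[C@H](CC[C@]2(C)O)C(C)(C)[C@@H]1CC[C@H]1[C@]2(C)CC[C@H](OC(=O)CCC(=O)O)C(C)(C)O[C@H]2CC[C@@]1(C)O`, likewise returns only the limit > 50000 nM. On the numbers shown, compound 2 therefore stands at the limit of > 50000 nM in this assay, at which 2 of the 2 values shown sit, with no measured value on either side of it and no step between measured compounds that could indicate a direction.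

Compound 3, `CC1=CC[C@H]2[C@H](CC[C@]2(C)O)C(C)(C)[C@@H]1CC[C@H]1[C@]2(C)CC[C@H](OC(=O)c3cccc(C(F)(F)F)c3)C(C)(C)O[C@H]2CC[C@@]1(C)O`, is the next compound to be measured in this assay. It differs from compound 2 by 3-(trifluoromethyl)phenyl in place of 2-carboxyethyl on a carbonyl carbon. Going by the values given here, with both values so far sitting as limits, no cause can be attached to the leaving or entering group, and no pattern can be claimed. The step from the measured limit is expected to be none beyond the scatter, so an at least 1.2-fold lower number from compound 2 to compound 3 (0.09 log units; that floor lies within the scatter) is the estimated change. Compound 3 is accordingly expected to give about 40000 nM in this assay, with a range from 8000 nM to 100000 nM, and a reported limit rather than a number remains the most likely outcome.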

Compound 3, half-maximal inhibitory concentration: 37900 nM
The estimate for compound 3 lay 1.1-fold (0.02 log units) above the measured number; the range from low to high includes it.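

In this assay, going by these compounds alone, the carbonyl carbon of the ester on the shared core now carries a group that returns a number: compound 3, with 3-(trifluoromethyl)phenyl in place of 2-carboxyethyl, gives 37900 nM as the first measured value. Compound 2 stays at the limit > 50000 nM and so supplies no number of its own. The change can be read only as an at least 1.3-fold lower number from compound 2 to compound 3 (0.12 log units; that floor lies within the scatter) and its full size stays unfixed, with one end of the step resting on a limit: the limit of > 50000 nM in this assay, at which 2 of the 3 values shown sit.

As far as these compounds go, it stays open whether the aromatic ring, the trifluoromethyl group or the loss of the 2-carboxyethyl chain accounts for the measured number in compound 3, since this single change alters all three at once. An unsubstituted phenyl on the same carbonyl carbon, or a longer chain ending in an amine, would be the comparisons needed to separate these parts and to show how far this position can move the read-out.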